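Series notes: difluorophenyl for methoxyphenyl on the carbonyl carbon

This account rests on a few compounds, and the source may have more. Where it says the series, first, only, none or still open, it means among the compounds named here.

Values in a functional assay on NCI-H23 cells (Homo sapiens) for inhibition, read by sulforhodamine B assay, with a stated time of 48 h (a higher number here means that more compound is tolerated, a lower number that less compound is tolerated), for the three measured compounds:
compound 1 `COc1cc(-c2cc(/C=C/C(=O)c3ccc(N)cc3)[nH]n2)cc(OC)c1OC` gives 73200 nM
compound 2 `COc1ccc(C(=O)/C=C/c2cc(-c3cc(OC)c(OC)c(OC)c3)n[nH]2)cc1OC` gives 22700 nM
compound 3 `COc1ccc(C(=O)/C=C/c2cc(-c3cc(OC)c(OC)c(OC)c3)n[nH]2)cc1` gives > 100000 nM, which is a limit of the assay and not a number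

Compound 3 stands at that limit; of the three values shown, it is the only one that sits there (the limit of > 100000 nM in this assay, at which 1 of the 3 values shown sits). The step to compound 4 `COc1cc(-c2cc(/C=C/C(=O)c3ccc(F)c(F)c3)[nH]n2)cc(OC)c1OC` is 3,4-difluorophenyl in place of 4-methoxyphenyl on a carbonyl carbon. Going by the values given here, no measured step changes the same group in the same way. Those that touch the aryl on the carbonyl carbon are a 3.2-fold lower number from compound 1 to compound 2 (0.51 log units; beyond the scatter) and an at least 4.4-fold higher number from compound 2 to compound 3 (0.64 log units; beyond the scatter), both modest, and an at least 1.3-fold higher number from compound 1 to compound 3 (0.13 log units; that floor lies within the scatter), which lies within the scatter at its floor. Among the compounds with values here, the change in this assay from compound 3 to compound 4 is therefore expected to be modest at most and its direction is uncertain; since compound 3 sits at a limit, a lower number is the only change that could be seen, and the expected step is an at least 1.6-fold lower number from compound 3 to compound 4 (0.22 log units; that floor lies within the scatter). Compound 4 is estimated at 60000 nM, between 20000 nM and 150000 nM.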

Compound 4, concentration lethal to 50% of the cells: > 100000 nM
Compound 4: a limit, no number; the forecaster's own chance of this, stated with the estimate: 40%; at least 1.6-fold (0.22 log units) between middle value and limit.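

In this assay compound 4 gives > 100000 nM, which is a limit of the assay and not a number. The 3,4-difluorophenyl on the carbonyl carbon thus puts compound 4 at the same limit as compound 3, and the step between these two limits cannot be read: the limit of > 100000 nM in this assay, at which 2 of the 4 values shown sit. Against the other aryl groups at this position, there is an at least 4.4-fold higher number from compound 2 to compound 4 (0.64 log units; beyond the scatter), which is beyond the scatter, and an at least 1.3-fold higher number from compound 1 to compound 4 (0.13 log units; that floor lies within the scatter), which does not separate compound 4 from compound 1.

As far as these compounds go, how far compound 3 and compound 4 lie past the limit stays unknown, so the 4-methoxyphenyl and the 3,4-difluorophenyl cannot be ranked. Also open, from the compounds shown here alone, is whether a monofluorophenyl or a phenyl carrying a nitrile on the carbonyl carbon would give a readable number in this assay.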